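This account rests on a few compounds, and the source may have more. Where it says the series, first, only, none or still open, it means among the compounds named here.

Among the measured compounds shown here, in an ADME assay (liver) for metabolic stability, with Liver microsome (Rattus norvegicus) as the target, using microsomes and NADPH, with a stated time of 30 min, tested at 1 uM (on this read-out higher numbers stand for fast clearance and lower numbers for slow clearance), compound 1 (`Cn1cc(-c2cc(C(O)(C(F)(F)F)C(F)(F)F)cnc2N2CCN(S(=O)(=O)c3ccc(N)nc3)CC2)cn1`) gives 44 mL.min-1.g-1 and compound 2 (`CCn1cc(-c2cc(C(O)(C(F)(F)F)C(F)(F)F)cnc2N2CCN(S(=O)(=O)c3ccc(N)nc3)CC2)cn1`) gives 194 mL.min-1.g-1 as the higher of the only two numbers so far. Compound 3 (`CC(C)n1cc(-c2cc(C(O)(C(F)(F)F)C(F)(F)F)cnc2N2CCN(S(=O)(=O)c3ccc(N)nc3)CC2)cn1`) differs from compound 2 by one change (methyl in place of hydrogen on a saturated chain carbon bound to an aromatic nitrogen and a saturated chain carbon), methyl in place of hydrogen on a saturated chain carbon bound to an aromatic nitrogen and a saturated chain carbon, so ethyl becomes isopropyl. For the measured compounds named here, one measured step bears on it, the modest 4.4-fold higher number from compound 1 to compound 2 (0.64 log units; beyond the scatter) beyond the scatter, where methyl also replaced hydrogen on a saturated chain carbon bound to an aromatic nitrogen. One step suggests a direction but fixes no size, so a smaller move the same way is expected. The estimated step is a 1.3-fold higher number from compound 2 to compound 3 (0.13 log units; within the scatter) and would not lie clearly beyond the scatter. For compound 3 the estimated value is 260 mL.min-1.g-1 with 110 mL.min-1.g-1 to 520 mL.min-1.g-1 as the expected range.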

Compound 3, intrinsic clearance in microsomes: 198 mL.min-1.g-1
Compound 3: the middle estimate sits 1.3-fold (0.12 log units) above what was measured; the measured number falls inside the stated range.
By their numbers in this assay, from the lowest: compound 1; then compounds 2 and 3 (each within the scatter of the next).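

In this assay, the change from ethyl to isopropyl gives a 1.0-fold higher number from compound 2 to compound 3 (0.01 log units; within the scatter), so the second methyl on this saturated chain carbon does not repeat the effect of the first, which gave a 4.4-fold higher number from compound 1 to compound 2 (0.64 log units; beyond the scatter). The step of isopropyl in place of methyl on the aromatic nitrogen gives a 4.5-fold higher number from compound 1 to compound 3 (0.65 log units; beyond the scatter), which places compound 1 clearly apart, while compound 2 and compound 3 remain within the scatter of each other. No measurement shown accounts for this levelling.

Still open, going by these compounds, is whether the level holds for a longer chain such as n-butyl, or for a tert-butyl or cyclopropyl group on the same nitrogen. Also open, on these data alone, is whether a hydroxyl or an amine on the ethyl chain would bring the number back towards that of compound 1.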